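The compounds below may be only part of what the source reports. "The series", "measured", "known", "first", "only" and "open" are said of these compounds alone.

Three compounds of this small series share a fused core and were tested in a functional assay (spleen, spleen) for activation, with Mus musculus as the target; on this read-out lower numbers stand for an effect already at smaller amounts and higher numbers for an effect only at larger amounts of compound. Compound 1 `COc1ccc(Cn2c(O)nc3c(N)ncnc32)cc1` gives 10 uM. Compound 2 `CCNc1nc(N)c2nc(O)n(Cc3ccccc3)c2n1` gives 1 uM, and compound 3 `CCc1nc(N)c2nc(O)n(Cc3ccccc3)c2n1` gives 1 uM. So compound 3 stands level with compound 2 at the digits shown, the two together holding the lowest numbers, while compound 1 lies a full order higher. For the measured compounds named here, the only single-point step recorded is no change at the digits printed from compound 2 to compound 3 (within the scatter), which shows that swapping ethylamino for ethyl at that position made no difference within the scatter.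

Compound 4 `Nc1nc(SCc2ccccc2)nc2c1nc(O)n2Cc1ccccc1` is the next member. The change is benzylsulfanyl in place of ethyl on an aromatic carbon. Going by the values given here, no measured step covers a group of this size at that position; the one recorded step there shows tolerance to a small exchange, and compound 1, which carries no group at that position at all, gives 10 uM. On that basis the number for compound 4 is expected to stay close to that of compound 3, with a step of no change at the digits printed from compound 3 to compound 4 (within the scatter) that may fall either way but is not expected to pass the scatter. The estimate for compound 4 is therefore 1 uM, with a range from 0.3 uM to 5 uM.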

Compound 4, minimum effective concentration: 0.1 uM
For compound 4 the middle estimate is 10-fold (1.00 log units) above the measured one; measured number below the stated range.
By their numbers in this assay, from the lowest: compound 4; then compounds 2 and 3 (each within the scatter of the next); then compound 1.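

In this assay, the position between two ring nitrogen atoms now proves sensitive to what sits on it: benzylsulfanyl in place of ethyl gives a 10-fold lower number from compound 3 to compound 4 (1.00 log units; beyond the scatter), and benzylsulfanyl in place of ethylamino gives a 10-fold lower number from compound 2 to compound 4 (1.00 log units; beyond the scatter). The earlier exchange, with no change at the digits printed from compound 2 to compound 3 (within the scatter), had suggested a position indifferent to change, but that result covers only ethylamino and ethyl. A much larger group, carrying a sulfur and a six-membered aromatic ring of carbon, is not merely accepted here but goes with an effect at smaller amounts of compound.

No measurement in hand accounts for this gain. From the compounds shown here alone, it also remains open whether the sulfur, the added ring or simply the greater length goes with the lower number: benzylamino or benzyloxy at this position would test the sulfur, while a plain butylsulfanyl chain would test the ring.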